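A few compounds are considered here, and "the series" means these few. Any claim that something is new, unique, unknown or untested is made for them only; others in the source may bear on it.

Three close analogues were examined in an ADME assay on Vero cells (Chlorocebus sabaeus) for cytotoxicity, with a stated time of 72 h; a lower number here means a stronger inhibitor, a higher number a weaker inhibitor. Compound 1 `Cn1nc(-c2ccc(F)cc2)cc1CO[C@@H]1COc2nc([N+](=O)[O-])cn2C1` gave > 128000 nM, which is a limit of the assay and not a number. Compound 2 `Cn1nc(-c2ccc(OC(F)(F)F)cc2)cc1CO[C@@H]1COc2nc([N+](=O)[O-])cn2C1` likewise gave > 128000 nM, again a limit rather than a number. Compound 3 `O=[N+]([O-])c1cn2c(n1)OC[C@@H](OCc1cnn(-c3ccc(F)cc3)c1)C2` gave > 128000 nM, also a limit of the assay. Compound 2 differs from compound 1 in one place, (trifluoromethoxy in place of fluoro on an aromatic carbon), and the result is a step that the two limits leave unreadable from compound 1 to compound 2 because of the limit of > 128000 nM in this assay, at which 3 of the 3 values shown sit. How the core of compound 3 differs from the core of compound 1 is not broken down here. Compound 4 `O=[N+]([O-])c1cn2c(n1)OC[C@@H](OCc1cnn(-c3ccc(OC(F)(F)F)cc3)c1)C2` has not yet been measured in this assay; it differs from compound 3 by the same change, (trifluoromethoxy in place of fluoro on an aromatic carbon). The step expected from compound 3 to compound 4 in this assay is estimated as a number no higher from compound 3 to compound 4 (the limit leaves the size open), resting on the fact that the earlier step was a step that the two limits leave unreadable from compound 1 to compound 2 and that (the limit of > 128000 nM in this assay, at which 3 of the 3 values shown sit). Compound 4 is therefore expected to give about 128000 nM in this assay. The estimated range for compound 4 runs from 64000 nM to 256000 nM.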

Compound 4, half-maximal inhibitory concentration: > 128000 nM
Compound 4 gave a limit, no number; the forecaster's own chance of this, stated with the estimate: 90%; the middle value lies on the limit itself.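

In this assay compound 4 gives > 128000 nM, a limit of the assay and not a number. No step can be read between compound 3 and compound 4 because both values are limits: the limit of > 128000 nM in this assay, at which 4 of the 4 values shown sit.

The compounds shown leave open whether trifluoromethoxy in place of fluoro changes the half-maximal inhibitory concentration in this assay at all.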